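The source may report more compounds than this note shows. Statements on the series, on what has been measured and on what is new or still open speak of the compounds shown alone.

Compound 1 `c1ccc(C(c2c[nH]c3ccccc23)c2c[nH]c3ccccc23)cc1`: 40000 nM
Compound 2 `COc1cccc(C(c2c[nH]c3ccc(Br)cc23)c2c[nH]c3ccc(Br)cc23)c1OC`: 100000 nM
Compound 3 `COc1ccc(C(c2c[nH]c3ccc(Br)cc23)c2c[nH]c3ccc(Br)cc23)c(OC)c1`: 100000 nM

In a functional assay on A549 cells (Homo sapiens) for inhibition, read by MTT assay, with a stated time of 48 h (on this read-out lower numbers stand for stronger inhibition and higher numbers for weaker inhibition), compound 3 gives 100000 nM, level with compound 2 and, together with it, the highest number of the three. Compound 1 gives a lower number, 40000 nM.

Compound 4 `Brc1ccc2[nH]cc(C(c3ccc4ccccc4c3)c3c[nH]c4ccc(Br)cc34)c2c1` has not yet been measured. It carries naphthalen-2-yl in place of 2,4-dimethoxyphenyl on a saturated chain carbon bound to two aromatic carbons.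

Within the data shown here, only one measured step touches this place: no change at the digits printed from compound 2 to compound 3 (within the scatter). Among the measured compounds shown here, that step only exchanges one dimethoxyphenyl group for another, and no measured compound carries naphthalen-2-yl, so it is a weak guide. A step beyond the scatter is therefore not expected in this assay, though a slight lean towards a lower number seems reasonable. That lean rests only on compound 1 at 40000 nM, whose core also differs.

The expected change is a 1.4-fold lower number from compound 3 to compound 4 (0.15 log units; within the scatter). For compound 4 the estimated value is 70000 nM, with an expected range from 25000 nM to 150000 nM.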

Compound 4, half-maximal inhibitory concentration: 8500 nM
Compound 4: middle estimate off by 8.2-fold (0.92 log units), on the high side; measured number outside the range, below it.
By their numbers in this assay, from the lowest: compound 4; then compound 1; then compounds 2 and 3 (each within the scatter of the next).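

In this assay, the saturated chain carbon bound to two aromatic carbons proves sensitive to the group it carries, which the exchange between dimethoxyphenyl groups did not reveal. Naphthalen-2-yl gives a 12-fold lower number from compound 3 to compound 4 (1.07 log units; beyond the scatter), and a 12-fold lower number from compound 2 to compound 4 (1.07 log units; beyond the scatter). The heavy-atom count stays the same, but the entering group has two six-membered aromatic rings of carbon only and no hydrogen-bond acceptors, and nothing measured here explains the drop.

These compounds cannot separate the effect of gaining the second ring from that of losing the methoxy groups, and compound 1 differs from compound 4 in more than one place, so it does not settle this. On these data alone, how naphthalen-1-yl or a phenyl ring with one methoxy group would behave at this carbon on the shared core also remains open.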